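Bromobenzyl shift in the cinnamate amide series

This account rests on a few compounds, and the source may have more. Where it says the series, first, only, none or still open, it means among the compounds named here.

Among the measured compounds shown here, in an assay on isolated protein with Bile acid receptor (Homo sapiens) as the target (on this read-out higher numbers stand for an effect only at larger amounts of compound and lower numbers for an effect already at smaller amounts), compound 1 `COC(=O)/C=C/c1cccc(N(Cc2ccc(-c3ccc(F)c(Cl)c3)cc2)C(=O)C2CCCCC2)c1` gives 66 nM and compound 2 `COC(=O)/C=C/c1cccc(N(Cc2ccc(-c3ccc(C(C)(C)C)cc3)cc2)C(=O)C2CCCCC2)c1` gives 132 nM; the step of a 2.0-fold higher number from compound 1 to compound 2 (0.30 log units; within the scatter) is the only measured step. For compound 3 `COC(=O)/C=C/c1cccc(N(Cc2ccccc2Br)C(=O)C2CCCCC2)c1` this assay reports only a limit, > 1000 nM. Compound 3 thus stands at the limit of > 1000 nM in this assay, at which 1 of the 3 values shown sits, without a number of its own. Compound 4 `COC(=O)/C=C/c1cccc(N(Cc2ccc(Br)cc2)C(=O)C2CCCCC2)c1` differs from compound 3 by 4-bromophenyl in place of 2-bromophenyl on a saturated chain carbon bound to an amide-type nitrogen. For the measured compounds named here, no measured step touches the bromophenyl, and the step from compound 1 to compound 2 changes a different group, so it gives no direct guide; the values of compound 1 and compound 2 only show that the shared core reaches measurable numbers with other benzyl groups. Compound 4 is therefore expected to move by an at least 1.6-fold lower number from compound 3 to compound 4 (0.22 log units; that floor lies within the scatter), with an estimate of 600 nM between 150 nM and 3000 nM in this assay.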

Compound 4, half-maximal effective concentration: > 1000 nM
Compound 4: only a limit was reported; the forecaster's own chance of this, stated with the estimate: 35%; at least 1.6-fold (0.22 log units) between middle value and limit.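

Compound 4, with 4-bromobenzyl in place of 2-bromobenzyl, also stops at a limit in this assay, as compound 3 does, so the steps between limits cannot be read: the limit of > 1000 nM in this assay, at which 2 of the 4 values shown sit.

With bromo in place of 4-(tert-butyl)phenyl the series shows an at least 7.5-fold higher number from compound 2 to compound 4 (0.87 log units; beyond the scatter), and with bromo in place of 3-chloro-4-fluorophenyl it shows an at least 15-fold higher number from compound 1 to compound 4 (1.18 log units; beyond the scatter). At this aromatic carbon, the two aryl groups of compound 1 and compound 2 therefore give numbers that bromo does not reach.

Open, as far as these compounds go, is whether a phenyl, a pyridine or a carboxylic acid at that carbon would restore a numbered value. Also open, from the compounds shown here alone, is whether 2-bromophenyl and 4-bromophenyl differ at all.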